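The source may hold more compounds than are shown below. What is called first, only, known or untested is meant among the compounds shown, and "the series" means these compounds.

Compound 1 `Cc1cc(S(=O)(=O)/N=C(\N)N/N=C/C#Cc2ccccc2)c(SCc2ccccc2C(F)(F)F)cc1Cl`: 16000 nM
Compound 2 `C/C(C#Cc1ccccc1)=N\N/C(N)=N/S(=O)(=O)c1cc(C)c(Cl)cc1SCc1ccccc1C(F)(F)F`: 21000 nM

In a functional assay on HeLa cells (Homo sapiens) for antiproliferative activity, read by MTT assay, with a stated time of 72 h (on this read-out lower numbers stand for stronger inhibition and higher numbers for weaker inhibition), compound 2 gives 21000 nM, and compound 1 gives 16000 nM; the two numbers lie within the scatter of each other. Compound 3 `C/C(C#Cc1ccccc1)=N\N/C(N)=N/S(=O)(=O)c1cc(C)c(Cl)cc1SCc1cccc2ccccc12` carries naphthalen-1-yl in place of 2-(trifluoromethyl)phenyl on a saturated chain carbon bound to a sulfur. For the measured compounds named here, no measured pair changes the group on the sulfur, so no step bears on this change directly; the only measured step, a 1.3-fold higher number from compound 1 to compound 2 (0.12 log units; within the scatter), altered a different position and stayed within the scatter. Compound 3 is therefore expected to stay close to compound 2, with a 1.1-fold lower number from compound 2 to compound 3 (0.02 log units; within the scatter) expected to remain within the scatter. The estimate for compound 3 is 20000 nM, ranging from 7000 nM to 60000 nM.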

Compound 3, half-maximal inhibitory concentration: 125000 nM
Estimate against measurement, compound 3: 6.3-fold (0.80 log units) below; measured number above the stated range.
By their numbers in this assay, from the lowest: compounds 1 and 2 (each within the scatter of the next); then compound 3.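

In this assay the group on a saturated chain carbon bound to a sulfur proves sensitive: naphthalen-1-yl in place of 2-(trifluoromethyl)phenyl gives a 6.0-fold higher number from compound 2 to compound 3 (0.77 log units; beyond the scatter) even though both groups count the same number of heavy atoms. The earlier step, a 1.3-fold higher number from compound 1 to compound 2 (0.12 log units; within the scatter) at a different place, gave no such sign. Nothing shown here accounts for the change.

As far as these compounds go, it remains open whether the rise follows from gaining naphthalen-1-yl or from losing trifluoromethyl, and whether plain phenyl or pyridin-2-yl on that carbon would stay near compound 2.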